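The source may hold more compounds than are shown below. What is called first, only, known or untested is meant among the compounds shown, and "the series" means these compounds.

Measured so far:

- compound 1, `O=C(Nc1ccc(-n2ncc3c(C(F)(F)F)cccc32)cc1)Nc1ccc(Cl)c(C(F)(F)F)c1`, in a functional assay on Bel-7402 cells (Homo sapiens) for cytotoxicity, read by MTT assay, with a stated time of 72 h (on this read-out lower numbers stand for stronger inhibition and higher numbers for weaker inhibition), gives 16000 nM.
- compound 2, `O=C(Nc1ccc(-n2ncc3c(Cl)cccc32)cc1)Nc1ccc(Cl)c(C(F)(F)F)c1`, in this assay gives 2500 nM.
- compound 3, `Cc1cccc2c1cnn2-c1ccc(NC(=O)Nc2ccc(Cl)c(C(F)(F)F)c2)cc1`, in this assay gives 6700 nM.

All three compounds share the same core and differ only in the group carried on one aromatic carbon of the fused ring system. On the numbers shown, compound 3 stands second highest of the three: compound 1 sits above it, by a 2.4-fold lower number from compound 1 to compound 3 (0.38 log units; beyond the scatter) taken in reverse, and compound 2 sits below it, as a 2.7-fold higher number from compound 2 to compound 3 (0.43 log units; beyond the scatter) shows. Compound 2 gives the lowest number of the three, and compound 1 the highest.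

Compound 4, `O=C(Nc1ccc(-n2ncc3ccccc32)cc1)Nc1ccc(Cl)c(C(F)(F)F)c1`, is not yet measured. It differs from compound 3 by hydrogen in place of methyl on an aromatic carbon.

Within the data shown here, no measured step swaps a methyl for a hydrogen, so the steps that bear on this change do so only indirectly. The step of a 2.4-fold lower number from compound 1 to compound 3 (0.38 log units; beyond the scatter) and the step of a 2.7-fold higher number from compound 2 to compound 3 (0.43 log units; beyond the scatter) together show that exchanging the group at this position moves the number modestly in either direction, with no group larger than the scatter apart from its neighbours by more than a small margin. Removing the methyl altogether is therefore expected to give a small shift at most, and its direction cannot be read from the three compounds. The estimated step of a 1.1-fold lower number from compound 3 to compound 4 (0.05 log units; within the scatter) is taken to lie close to the scatter. Compound 4 is thus expected to give about 6000 nM in this assay, within a range from 2500 nM to 15000 nM.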

Compound 4, half-maximal inhibitory concentration: 10600 nM
Compound 4: the middle estimate sits 1.8-fold (0.25 log units) below what was measured; the range from low to high includes it.
By their numbers in this assay, from the lowest: compound 2; then compounds 3, 4 and 1 (each within the scatter of the next, the first and the last beyond it).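

Among these compounds, compound 4 supplies the reference that the earlier compounds lacked: the same core with only hydrogen at this position. In this assay, neither methyl (a 1.6-fold higher number from compound 3 to compound 4 (0.20 log units; within the scatter)) nor trifluoromethyl (a 1.5-fold lower number from compound 1 to compound 4 (0.18 log units; within the scatter)) can be told apart from hydrogen, as both steps lie within the scatter, whereas chloro does stand apart (a 4.2-fold higher number from compound 2 to compound 4 (0.63 log units; beyond the scatter)), a step beyond the scatter towards a higher number when chloro gives way to hydrogen. Among these four compounds, then, only chloro changes the number measurably relative to hydrogen, although no information is available on what lies behind this result.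

The compounds shown leave open whether the lower number seen with chloro is particular to that group or would also appear with fluoro or bromo on the same aromatic carbon. They also leave open how an amine or a methoxy group at this position would compare with hydrogen and chloro, and whether the chloro result would hold if the rest of the molecule were changed.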